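Phenyl for trifluoromethyl on the benzamide of compound 2

The compounds below may be only part of what the source reports. "The series", "measured", "known", "first", "only" and "open" are said of these compounds alone.

Measured compounds:
Compound 1, `Cc1ccc(NC(=O)c2cccc(C(F)(F)F)c2)cc1N1Cc2cnc(Nc3ccc(C)c(C(F)(F)F)c3)nc2N(C)C1=O`: in an ADME assay on BaF3 cells (Mus musculus) for antiproliferative activity, read by CellTiter-Glo and CCK-8 assay, with a stated time of 72 h (on this read-out higher numbers stand for weaker inhibition of growth and lower numbers for stronger inhibition of growth), compound 1 gives > 10000 nM, which is a limit of the assay.
Compound 2, `Cc1ccc(Nc2ncc3c(n2)N(C)C(=O)N(c2cc(NC(=O)c4cccc(C(F)(F)F)c4)ccc2C)C3)cc1N`: in this assay compound 2 gives 440 nM.

Among the compounds with values here, compound 2 holds the only numeric value in this assay; the other entry is the limit of > 10000 nM in this assay, at which 1 of the 2 values shown sits. Within the data shown here, the single measured step, an at least 22-fold lower number from compound 1 to compound 2 (1.35 log units; beyond the scatter), concerns the aniline end of the molecule and not the benzamide. Compound 3, `Cc1ccc(Nc2ncc3c(n2)N(C)C(=O)N(c2cc(NC(=O)c4cccc(-c5ccccc5)c4)ccc2C)C3)cc1N`, differs from compound 2 by phenyl in place of trifluoromethyl on an aromatic carbon. Among the measured compounds shown here, no measured step touches this position, so the known step offers no guide to the size or direction of the change. For the measured compounds named here, replacing trifluoromethyl by phenyl here has no precedent, and a step no larger than the scatter is expected, with wide uncertainty. For compound 3 the estimate in this assay is 600 nM, within 150 nM to 2500 nM. The expected step is a 1.4-fold higher number from compound 2 to compound 3 (0.13 log units; within the scatter).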

Compound 3, concentration for 50% growth inhibition: > 10000 nM
Compound 3 gave a limit, no number (the forecaster's own chance of this, stated with the estimate: 5%); middle value at least 16-fold (1.22 log units) from the limit.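

The benzamide position is not a free one: phenyl in place of trifluoromethyl on this aromatic carbon gives an at least 22-fold higher number from compound 2 to compound 3 (1.35 log units; beyond the scatter) in this assay. The amino group on the aniline end, present in both compound 2 and compound 3, therefore does not secure a measurable value by itself, and growth inhibition in this series depends on the benzamide end as well. Compound 3 sits at a limit of the assay and not at a number, so the step has a lower bound only: the limit of > 10000 nM in this assay, at which 2 of the 3 values shown sit.

With a single replacement at this position, the result cannot separate the loss of trifluoromethyl from the arrival of a second ring. A chlorine, a methyl, a methoxy group or a dimethylamino group here would show how much change this position tolerates.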